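Pentyl on Selenium and Growth Inhibition of Breast Cells

The compounds below may be only part of what the source reports. "The series", "measured", "known", "first", "only" and "open" are said of these compounds alone.

Compound 1, `CCCCC[Se]c1nc(NCc2ccccc2)c2ccccc2n1`: > 100000 nM
Compound 2, `[SeH]c1nc(NCc2ccccc2)c2ccccc2n1`: 63600 nM
Compound 3, `Nc1nc([SeH])nc2ncccc12`: 31100 nM

Of the compounds shown here, three have been measured in an ADME assay on 184B5 cells (Homo sapiens) for cytotoxicity, read by MTT assay, with a stated time of 72 h; a lower number here means a stronger inhibitor of growth, a higher number a weaker inhibitor of growth. Compound 1 reaches only a limit of this assay and not a number, (the limit of > 100000 nM in this assay, at which 1 of the 3 values shown sits). Compound 2 gives 63600 nM in this assay, and compound 3 gives 31100 nM, the lower of the two numbers. How the core of compound 2 differs from the core of compound 3 is not broken down here. The step of an at least 1.5-fold higher number from compound 2 to compound 1 (0.19 log units; that floor lies within the scatter) comes with pentyl in place of hydrogen on a selenium. Compound 4, `CCCCC[Se]c1nc(N)c2cccnc2n1`, is still unmeasured; it differs from compound 3 by pentyl in place of hydrogen on a selenium, the same change. Given the earlier step, compound 4 is expected to give a higher number than compound 3, a 2.1-fold higher number from compound 3 to compound 4 (0.32 log units; beyond the scatter). The estimate for compound 4 in this assay is 65000 nM, expected to lie between 30000 nM and 150000 nM.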

Compound 4, concentration for total growth inhibition: 40200 nM
The estimate for compound 4 lay 1.6-fold (0.21 log units) above the measured number; measured number inside the range.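

In this assay, pentyl in place of hydrogen on a selenium gives a 1.3-fold higher number from compound 3 to compound 4 (0.11 log units; within the scatter), so on this core the change cannot be told apart from no change. Set beside the same change on the other core, the result reads: the same change on two cores in this assay, an at least 1.5-fold higher number (0.19 log units; that floor lies within the scatter) from compound 2 to compound 1 and a 1.3-fold higher number (0.11 log units; within the scatter) from compound 3 to compound 4; the limit leaves it open whether they differ

Neither step is shown to lie beyond the scatter, and with compound 1 reported only as a limit, the series shows neither that the change carries over equally nor that the two cores respond differently. The compounds shown leave open whether any group other than pentyl would shift the number in this assay. They also leave open how the change behaves on any third core.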